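A few compounds are considered here, and "the series" means these few. Any claim that something is new, unique, unknown or untested is made for them only; others in the source may bear on it.

Compound 1 `COc1cccc(OC)c1OCCNCCOc1ccccc1OCc1cccc(Cl)c1` gives 20400 nM in a functional assay on PC-3 cells (Homo sapiens) for cytotoxicity, read by sulforhodamine B assay; a higher number here means a weaker inhibitor of growth, a lower number a stronger inhibitor of growth.
Compound 2 `COc1cccc(OC)c1OCCNCCOc1ccccc1OCc1ccc(C)cc1` gives 27500 nM in this assay.
Compound 3 `COc1cccc(OC)c1OCCNCCOc1ccccc1OCc1cccc([N+](=O)[O-])c1` gives 38900 nM in this assay.

Compound 3 carries the highest of the three numbers, but its separation from compound 2, a 1.4-fold higher number from compound 2 to compound 3 (0.15 log units; within the scatter), and from compound 1, a 1.9-fold higher number from compound 1 to compound 3 (0.28 log units; within the scatter), both lie within the scatter, so on these data the three compounds stand level. Compound 4 `COc1ccc(COc2ccccc2OCCNCCOc2c(OC)cccc2OC)cc1` differs from compound 3 in one place: 4-methoxyphenyl in place of 3-nitrophenyl on a saturated chain carbon bound to an oxygen on an aromatic ring. The measured steps that bear on this change are the two that swap the group on that same saturated chain carbon, a 1.3-fold higher number from compound 1 to compound 2 (0.13 log units; within the scatter) and a 1.4-fold higher number from compound 2 to compound 3 (0.15 log units; within the scatter), and the exchange of a single substituent on the aromatic ring, a 1.9-fold higher number from compound 1 to compound 3 (0.28 log units; within the scatter). Going by the values given here, none of them moved the number beyond the scatter, and no measured compound carries a methoxy group on that ring, so the set gives no pointer to a step in either direction. Compound 4 is therefore expected to show no step beyond the scatter, a 1.3-fold lower number from compound 3 to compound 4 (0.11 log units; within the scatter). Compound 4 is estimated at 30000 nM, with a range from 12000 nM to 80000 nM.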

Compound 4, concentration for total growth inhibition: 34700 nM
Estimate against measurement, compound 4: 1.2-fold (0.06 log units) below; the range from low to high includes it.
By their numbers in this assay, from the lowest: compounds 1, 2, 4 and 3 (each within the scatter of the next).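

With 4-methoxyphenyl on the saturated chain carbon bound to an oxygen on an aromatic ring, the set gains its first methoxy group on that ring, and in this assay this group stays within the scatter of all three earlier groups: a 1.1-fold lower number from compound 3 to compound 4 (0.05 log units; within the scatter), a 1.3-fold higher number from compound 2 to compound 4 (0.10 log units; within the scatter) and a 1.7-fold higher number from compound 1 to compound 4 (0.23 log units; within the scatter). Across these four compounds, then, 3-chlorophenyl, 4-methylphenyl, 3-nitrophenyl and 4-methoxyphenyl stand level at this place, and no compound among them goes against that, even though the exchange of 3-nitrophenyl for 4-methoxyphenyl also changes the position named for the substituent and replaces a group of 9 heavy atoms with one of 8. No measurement is available that would explain this flat picture.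

As far as these compounds go, all four compounds keep the shared core and a substituted phenyl at this place, so it remains open whether an amine or a carboxylic acid on that ring would produce a step beyond the scatter. From the compounds shown here alone, it also remains open whether a longer chain between the oxygen and the ring, or a change elsewhere in the core, would do so.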